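The source may report more compounds than this note shows. Statements on the series, on what has been measured and on what is new or still open speak of the compounds shown alone.

Series in a functional assay on PC-3 cells (Homo sapiens) for inhibition, read by MTT assay, with stated times of 18 h and 4 h; on this read-out lower numbers stand for stronger inhibition and higher numbers for weaker inhibition:
- compound 1 `CCCCCCCCCCCCCCCCOP(=O)(O)OCCSC(=S)N1CCCCCC1`: 32100 nM
- compound 2 `CCCCCCCCCCOP(=O)(O)OCCSC(=S)N1CCCCCC1`: 32900 nM
- compound 3 `CCCCCCCCOP(=O)(O)OCCSC(=S)N1CCCCC1`: > 100000 nM (a limit of the assay, not a number)

Compound 1 shares the numerical end of the series with compound 2, the two lying within the scatter of each other: a 1.0-fold higher number from compound 1 to compound 2 (0.01 log units; within the scatter). Compound 3 marks (the limit of > 100000 nM in this assay, at which 1 of the 3 values shown sits).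

Next is compound 4 `CCCCCCCCCCCCCCCCOP(=O)(O)OCCSC(=S)N1CCN(C)CC1`, with 4-methylpiperazin-1-yl in place of azepan-1-yl on a thiocarbonyl carbon. For the measured compounds named here, the only measured step concerns the chain, not this place, and it stays within the scatter, so it gives no size for the present change. Going by the values given here, no measured step changes the group on the thiocarbonyl carbon alone. Among the compounds with values here, the limit reached by compound 3, at the limit of > 100000 nM in this assay, at which 1 of the 3 values shown sits, shows only that a member of the series can leave the measurable range, so a modest move towards weaker inhibition is expected, with a wide margin. The expected step is a 1.5-fold higher number from compound 1 to compound 4 (0.17 log units; within the scatter). For compound 4 the estimated value is 48000 nM, with an expected range of 18000 nM to 100000 nM.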

Compound 4, half-maximal inhibitory concentration: 95200 nM
Compound 4: middle estimate off by 2.0-fold (0.30 log units), on the low side; the range from low to high includes it.
By their numbers in this assay, from the lowest: compounds 1 and 2 (each within the scatter of the next); then compound 4. At a limit, above all of these: compound 3.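

In this assay, 4-methylpiperazin-1-yl in place of azepan-1-yl on a thiocarbonyl carbon gives a 3.0-fold higher number from compound 1 to compound 4 (0.47 log units; beyond the scatter), towards weaker inhibition. This is the first single-place change in the series to go beyond the scatter, whereas the chain step, a 1.0-fold higher number from compound 1 to compound 2 (0.01 log units; within the scatter), stays within it, so the group at this place is the one shown so far to shift the read-out. Nothing given here bears on why this step arises.

With only one replacement shown for azepan-1-yl, ring size and the second ring nitrogen of 4-methylpiperazin-1-yl cannot be told apart. Going by these compounds, how a morpholin-4-yl or an open-chain diethylamino group on the thiocarbonyl carbon would read on the chain of compound 1 remains open.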